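Shortening the Link Between Ring and Acetamide

The source may hold more compounds than are shown below. What is called first, only, known or untested is meant among the compounds shown, and "the series" means these compounds.

Measured compounds:
compound 1, `CCSC(=S)SCC(=O)c1cccc(NC(=O)c2ccccc2)c1`, 65 nM
compound 2, `CCSC(=S)SCC(=O)c1cccc(CNC(C)=O)c1`, 816 nM

Both compounds were tested in an assay on HEK293 cells for inhibition of protein deacetylase HDAC6 (Homo sapiens); on this read-out higher numbers stand for weaker inhibition and lower numbers for stronger inhibition. Compound 2 gives the highest of the two numbers shown, 816 nM, while compound 1 gives 65 nM; the gap between these two values lies beyond the usual scatter of the assay, so compound 1 is the stronger inhibitor of the pair. No single-point comparison between compound 1 and compound 2 is available, as their structures differ in more than one respect.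

Compound 3, `CCSC(=S)SCC(=O)c1cccc(NC(C)=O)c1`, has not yet been measured. It differs from compound 2 in one place: acetamido in place of acetamidomethyl on an aromatic carbon. In words, acetamido takes the place of acetamidomethyl on an aromatic carbon, so the amide nitrogen now sits directly on the ring, as it does in compound 1. On this basis compound 3 is expected to show a step from compound 2 toward a lower number, estimated as a 3.3-fold lower number from compound 2 to compound 3 (0.51 log units; beyond the scatter), somewhat beyond the scatter. Compound 3 is estimated at 250 nM, with a likely range from 80 nM to 800 nM.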

Compound 3, half-maximal inhibitory concentration: 329 nM
Estimate against measurement, compound 3: 1.3-fold (0.12 log units) below, and the stated range covers the measured number.
By their numbers in this assay, from the lowest: compound 1; then compound 3; then compound 2.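

On this aromatic carbon, acetamido in place of acetamidomethyl gives in this assay a 2.5-fold lower number from compound 2 to compound 3 (0.39 log units; beyond the scatter) and shows that this single change in the link between ring and amide is enough to move the number beyond the scatter. With the amide nitrogen directly on the ring, methyl in place of phenyl on the carbonyl carbon gives a 5.1-fold higher number from compound 1 to compound 3 (0.70 log units; beyond the scatter) and shows that the group on the far side of the amide also moves the number beyond the scatter, something the first two compounds could not show while they differed in more than one respect. No available measurement explains why either change acts as it does.

As far as these compounds go, it remains open whether a longer link, such as acetamidoethyl, would continue the trend seen on going from acetamido to acetamidomethyl, and what a plain amine on the same aromatic carbon would give. On the carbonyl carbon only methyl and phenyl are shown, so the place of an ethyl or a cyclohexyl group there relative to these two cannot be told.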